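Swapping Methyl for Fluoro on Compound 2

The source may hold more compounds than are shown below. What is called first, only, known or untested is meant among the compounds shown, and "the series" means these compounds.

In a functional assay on HCT-116 cells (Homo sapiens) for cytotoxicity, read by MTT assay, with a stated time of 72 h (a higher number here means a weaker inhibitor, a lower number a stronger inhibitor), compound 2 `Cc1ccc(S(=O)(=O)c2nc3ccccc3nc2N2CCC(O)CC2)cc1` gives 5440 nM. Going by the values given here, that is the lower of the two numbers so far, and the gap to compound 1 `O=S(=O)(c1ccc(F)cc1)c1nc2ccccc2nc1N1CCc2ccccc2C1`, at 16600 nM, lies beyond the usual scatter of repeated measurements. Compound 2 is therefore the stronger of this pair, although the two structures differ in more than one place. Compound 3 `O=S(=O)(c1ccc(F)cc1)c1nc2ccccc2nc1N1CCC(O)CC1` departs from compound 2 in a single change, 4-methylphenyl to 4-fluorophenyl: fluoro in place of methyl on an aromatic carbon. Among the compounds with values here, no measured pair here shows this swap on its own, so the forecast stays cautious. The expected step, a 1.1-fold higher number from compound 2 to compound 3 (0.04 log units; within the scatter), is small and within the scatter, with no firm direction. Compound 3 is estimated at 6000 nM, with an expected range from 2500 nM to 15000 nM.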

Compound 3, half-maximal inhibitory concentration: 1340 nM
For compound 3 the middle estimate is 4.5-fold (0.65 log units) above the measured one; the measured number lies below the stated range.
By their numbers in this assay, from the lowest: compound 3; then compound 2; then compound 1.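

In this assay fluoro in place of methyl on the aromatic carbon gives a 4.1-fold lower number from compound 2 to compound 3 (0.61 log units; beyond the scatter), so this position on the six-membered aromatic ring responds to a change of a single heavy atom. With the 4-fluorophenyl group held constant, 4-hydroxypiperidin-1-yl in place of 1,2,3,4-tetrahydroisoquinolin-2-yl gives a 12-fold lower number from compound 1 to compound 3 (1.09 log units; beyond the scatter), which shows that a second place on the shared core also matters in this assay. Nothing available here explains either step.

Going by these compounds, only methyl and fluoro are compared at this position, so it remains open whether chloro, methoxy or a nitrile would give a lower or a higher number. On these data alone, it is also open whether the swap from methyl to fluoro would give a similar step in compounds carrying the 1,2,3,4-tetrahydroisoquinolin-2-yl group.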